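Removing one ring methyl from compound 3

This account rests on a few compounds, and the source may have more. Where it says the series, first, only, none or still open, it means among the compounds named here.

In an ADME assay on the whole organism (strain Sprague-Dawley) for pharmacokinetics, with Rattus norvegicus as the target, read by LC-MS, using cassette dosing, at a dose of 0.5 mg/kg by the intravenous route (a lower number here means slower removal, a higher number faster removal of the compound), compound 3 (`Cc1cc(C#N)cnc1C(=O)Nc1ccc(F)c([C@]2(C)C=C(CF)OC(N)=N2)c1`) gives 21.8 mL/min/kg and lies within the usual scatter of both compound 2 (`C[C@@]1(c2cc(NC(=O)c3ncc(C#N)cc3Cl)ccc2F)C=C(CF)OC(N)=N1`) at 30.6 mL/min/kg and compound 1 (`COCC1=C[C@@](C)(c2cc(NC(=O)c3ccc(C#N)cn3)ccc2F)N=C(N)O1`) at 12.9 mL/min/kg as well. Compound 4 (`C[C@@]1(c2cc(NC(=O)c3ccc(C#N)cn3)ccc2F)C=C(CF)OC(N)=N1`) has hydrogen in place of methyl on an aromatic carbon. One measured step involves that carbon: a 1.4-fold lower number from compound 2 to compound 3 (0.15 log units; within the scatter) when methyl replaced chloro, and it stays within the scatter. The 5-cyanopyridin-2-yl group of compound 4 also occurs in compound 1 at 12.9 mL/min/kg though compound 1 differs elsewhere too. Expected here is a 1.1-fold lower number from compound 3 to compound 4 (0.04 log units; within the scatter) and so no step beyond the scatter. Compound 4 is expected at 20 mL/min/kg with a range of 11 mL/min/kg to 36 mL/min/kg as the estimate.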

Compound 4, clearance: 16.8 mL/min/kg
Compound 4: the middle estimate sits 1.2-fold (0.08 log units) above what was measured; low and high end bracket the measured number.
By their numbers in this assay, from the lowest: compounds 1, 4, 3 and 2 (each within the scatter of the next, the first and the last beyond it).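

With hydrogen, methyl or chloro on this aromatic carbon of the pyridine, clearance in this assay does not separate: hydrogen in place of methyl gives a 1.3-fold lower number from compound 3 to compound 4 (0.11 log units; within the scatter), and hydrogen in place of chloro gives a 1.8-fold lower number from compound 2 to compound 4 (0.26 log units; within the scatter). On the chain carbon, fluoro in place of methoxy gives a 1.3-fold higher number from compound 1 to compound 4 (0.11 log units; within the scatter), so neither single change moves clearance beyond the scatter. No measurement here explains these numbers. From the compounds shown here alone, whether an amine or a trifluoromethyl group on this aromatic carbon would move clearance beyond the scatter stays open, as does the result of a hydroxyl group on the chain carbon.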